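This account rests on a few compounds, and the source may have more. Where it says the series, first, only, none or still open, it means among the compounds named here.

Three ureas built on one shared core have been measured in an assay on CHO cells for displacement of a labelled ligand from histamine receptor H3 (Macaca mulatta), read by scintillation counting, with a stated time of 1 h; a lower number here means a stronger inhibitor, a higher number a weaker inhibitor. Compound 1 `Cc1cc(NC(=O)Nc2cc(Cl)cc(Cl)c2)ccc1N1CCC(N2CCCC2C)C1` gives 43 nM, compound 2 `Cc1cc(NC(=O)N2CCN(C)CC2)ccc1N1CCC(N2CCCC2C)C1` gives 12.7 nM, and compound 3 `CC(=O)N(C)C1CCN(C(=O)Nc2ccc(N3CCC(N4CCCC4C)C3)c(C)c2)C1` gives 89.7 nM. Compound 3 therefore stands at the highest number of the three: compound 1 lies nearest, with a 2.1-fold higher number from compound 1 to compound 3 (0.32 log units; beyond the scatter) separating them, and compound 2 lies furthest, with a 7.1-fold higher number from compound 2 to compound 3 (0.85 log units; beyond the scatter) separating them.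

Compound 4 `Cc1cc(NC(=O)NCc2cccs2)ccc1N1CCC(N2CCCC2C)C1` differs from compound 3 only at the carbonyl carbon, where (((thiophen-2-yl)methyl)amino in place of 3-(acetyl(methyl)amino)pyrrolidin-1-yl on a carbonyl carbon). Going by the values given here, the steps that bear on this position are the three already seen, all of which arise from exchanging the group on the carbonyl carbon: a 3.4-fold lower number from compound 1 to compound 2 (0.53 log units; beyond the scatter), a 2.1-fold higher number from compound 1 to compound 3 (0.32 log units; beyond the scatter) and a 7.1-fold higher number from compound 2 to compound 3 (0.85 log units; beyond the scatter). Each is modest, and every exchange away from the 3-(acetyl(methyl)amino)pyrrolidin-1-yl group of compound 3 has so far given a lower number. Compound 4 carries an amino group with a hydrogen-bond donor at the carbonyl carbon, as compound 1 does, and compound 1 sits at 43 nM. On that basis compound 4 is expected to show a modest step downward, estimated as a 2.6-fold lower number from compound 3 to compound 4 (0.41 log units; beyond the scatter) in this assay, without reaching the number of compound 2. The estimated value for compound 4 in this assay is 35 nM, with a range from 12 nM to 100 nM.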

Compound 4, inhibition constant: 8.4 nM
Compound 4: middle estimate off by 4.2-fold (0.62 log units), on the high side; the measured number lies below the stated range.
By their numbers in this assay, from the lowest: compounds 4 and 2 (each within the scatter of the next); then compound 1; then compound 3.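

At the carbonyl carbon, ((thiophen-2-yl)methyl)amino in place of 3-(acetyl(methyl)amino)pyrrolidin-1-yl gives the widest step yet seen at this position in this assay (an 11-fold lower number from compound 3 to compound 4 (1.03 log units; beyond the scatter)), showing that this group can move the number further than the three earlier compounds revealed. Two very different groups now cannot be told apart, 4-methylpiperazin-1-yl and ((thiophen-2-yl)methyl)amino (a 1.5-fold lower number from compound 2 to compound 4 (0.18 log units; within the scatter)), while the amide hydrogen present in both compound 1 and compound 4 does not by itself set the number: on that amide-type nitrogen, (thiophen-2-yl)methyl in place of 3,5-dichlorophenyl still gives a step beyond the scatter (a 5.1-fold lower number from compound 1 to compound 4 (0.71 log units; beyond the scatter)). Nothing given here accounts for these differences.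

The compounds shown do not separate the contribution of the thiophene ring from that of its methyl link, a question that a benzyl or furan-2-ylmethyl group, or a longer chain such as 2-(thiophen-2-yl)ethyl, would address. As far as these compounds go, all four compounds also share one core, so whether this order of groups holds on a different core remains open.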